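The compounds below may be only part of what the source reports. "The series", "measured", "known", "first", "only" and "open" are said of these compounds alone.

Compound 1 (`COc1ccccc1OCC1SCCN1C(=O)C[S+](C)[O-]`) is the starting point here. Going by the values given here, in a functional assay on the whole organism (trachea) for inhibition, with Cavia porcellus as the target (a lower number here means that less compound is needed, a higher number that more compound is needed for the effect), compound 1 gives 10 mg/kg, the lowest number among the three compounds measured so far. Compound 2 (`COc1ccccc1OCC1N(C(=O)C[S+](C)[O-])CC[S+]1[O-]`) gives 25 mg/kg and compound 3 (`O=C(Cn1ccnc1)N1CCSC1COc1ccccc1O`) gives 27 mg/kg. Both numbers lie beyond the usual scatter from that of compound 1, so more of either compound is needed for the effect.

The next compound, compound 4 (`COc1ccccc1OCC1SCCN1C(=O)CC(C)=O`), keeps the core of compound 1 and exchanges one side group: a group of 3 heavy atoms (2 carbon, 1 oxygen; no ring) in place of a group of 3 heavy atoms (1 carbon, 1 oxygen, 1 sulfur; no ring), on a saturated chain carbon bound to a carbonyl carbon. An acetyl enters on a saturated chain carbon bound to a carbonyl carbon, replacing a group with no common name. Among the compounds with values here, no measured pair shows this exchange on its own, so the data offer no direct step to lean on. The count of heavy atoms stays the same, and the expectation in this assay is for no step beyond the scatter. Within the data shown here, there is a slight lean toward a higher number, which rests on compound 1 holding the lowest number so far at 10 mg/kg. The estimated step is a 1.5-fold higher number from compound 1 to compound 4 (0.18 log units; within the scatter), which is expected to stay within the scatter. For compound 4 the expected value is 15 mg/kg, with an estimated range from 5 mg/kg to 45 mg/kg.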

Compound 4, dose for half-maximal effect: 26 mg/kg
Compound 4: middle estimate off by 1.7-fold (0.24 log units), on the low side; low and high end bracket the measured number.
By their numbers in this assay, from the lowest: compound 1; then compounds 2, 4 and 3 (each within the scatter of the next).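

In this assay, placing acetyl on a saturated chain carbon bound to a carbonyl carbon, where compound 1 has a group of no common name containing sulfur, gives a 2.6-fold higher number from compound 1 to compound 4 (0.41 log units; beyond the scatter). Going by these compounds alone, this is the first step in the set that changes only one place, and it shows that this position is sensitive to the exchange: both groups have 3 heavy atoms and 1 hydrogen-bond acceptor and carry no net charge, yet more of compound 4 is needed for the effect, so matching these counts does not preserve the number. Nothing available here explains why this exchange changes the number, and the finding rests on this single pair.

The compounds shown leave open how other groups at this place, such as an amine, a carboxylic acid or a longer chain, would compare with the group in compound 1. They also leave open whether the same exchange would give a step of similar size if the rest of compound 1 were changed, for example on a core carrying a free phenol hydroxyl in place of the methoxy group.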